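A Free Phenol in Place of a Sulfonate Ester

The compounds below may be only part of what the source reports. "The series", "measured", "known", "first", "only" and "open" are said of these compounds alone.

Compound 1 `C=C1C[C@]23C[C@@]1(O)CC[C@H]2c1ccc(OS(=O)(=O)c2ccc(C)cc2)c(C)c1[C@@H]3Cn1cc(-c2ccc(Cl)cc2)nn1` in a functional assay on A549 cells (Homo sapiens) for cytotoxicity, read by MTT assay, with a stated time of 4 days (on this read-out higher numbers stand for weaker inhibition and lower numbers for stronger inhibition), gives > 20000 nM, a limit of the assay rather than a number.
Compound 2 `C=C1C[C@]23C[C@@]1(O)CC[C@H]2c1ccc(OS(=O)(=O)c2ccc(C)cc2)c(C)c1[C@@H]3Cn1cc(-c2ccc(Br)cc2)nn1` in this assay gives > 20000 nM, again a limit.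
Compound 3 `C=C1C[C@]23C[C@@]1(O)CC[C@H]2c1ccc(OS(=O)(=O)c2ccc(C)cc2)c(C)c1[C@@H]3Cn1cc(-c2ccc(F)cc2)nn1` in this assay gives > 20000 nM, also a limit.

All three measured compounds carry the same core and differ only in the halogen on the aromatic ring attached to the triazole. None of the three steps between them can be read: a step that the two limits leave unreadable from compound 1 to compound 2, a step that the two limits leave unreadable from compound 1 to compound 3 and a step that the two limits leave unreadable from compound 2 to compound 3 all run from one limit to another, as summed up by the limit of > 20000 nM in this assay, at which 3 of the 3 values shown sit. Compound 3 therefore stands where the others do, at a limit and without a measured number.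

Compound 4 `C=C1C[C@]23C[C@@]1(O)CC[C@H]2c1ccc(O)c(C)c1[C@@H]3Cn1cc(-c2ccc(F)cc2)nn1` is the unmeasured compound. It differs from compound 3 in one place: hydrogen in place of (4-methylphenyl)sulfonyl on an oxygen on an aromatic ring. Within the data shown here, none of the measured steps touches this position; all of them concern the halogen on the distant aromatic ring, and none gives a readable size. The data give no basis for predicting the direction or size of the step from compound 3 to compound 4, so the expected step of an at least 1.3-fold lower number from compound 3 to compound 4 (0.12 log units; that floor lies within the scatter) is only a guess carrying wide uncertainty. Compound 4 is estimated at 15000 nM, within a range from 3000 nM to 60000 nM, with a real chance that this assay again reports only a limit.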

Compound 4, half-maximal inhibitory concentration: > 20000 nM
Compound 4: only a limit was reported (the forecaster's own chance of this, stated with the estimate: 55%); middle value at least 1.3-fold (0.12 log units) away from the limit.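

Compound 4 ends at a limit, as compound 3 does, so the step between them, hydrogen in place of (4-methylphenyl)sulfonyl on the oxygen, cannot be read: the limit of > 20000 nM in this assay, at which 4 of the 4 values shown sit.

The compounds shown leave open whether either the halogen or this change on the oxygen moves the read-out in this assay at all, and by how much.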